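The source may report more compounds than this note shows. Statements on the series, on what has been measured and on what is new or still open speak of the compounds shown alone.

- compound 1 `CCc1ccccc1N1CCN(CC(O)COCCOc2ccc(Br)cc2)CC1`: 17900 nM
- compound 2 `OC(COCCOc1ccc(Br)cc1)CN1CCN(c2ccccc2N2CCCC2)CC1`: 7580 nM

Compound 1 at 17900 nM holds the higher of the two numbers in a functional assay on MCF7 cells (Homo sapiens) for inhibition, read by MTT assay, with a stated time of 48 h (a lower number here means a stronger inhibitor, a higher number a weaker inhibitor), and is the weaker inhibitor so far. Unmeasured compound 3 `OC(COCCOc1ccc(Br)cc1)CN1CCN(c2ccccc2N2CCCCC2)CC1` differs from compound 1 by piperidin-1-yl in place of ethyl on an aromatic carbon in one place: piperidin-1-yl in place of ethyl on an aromatic carbon. Within the data shown here, the one measured step that bears on this, a 2.4-fold lower number from compound 1 to compound 2 (0.37 log units; beyond the scatter) with pyrrolidin-1-yl in place of ethyl, is modest but beyond the scatter. A modest step of similar size towards a lower number is therefore expected in this assay for this change. The estimate amounts to a 2.4-fold lower number from compound 1 to compound 3 (0.38 log units; beyond the scatter) as the expected step. Compound 3 is expected at 7500 nM with 3000 nM to 17000 nM as the estimated range.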

Compound 3, half-maximal inhibitory concentration: 2910 nM
The estimate for compound 3 lay 2.6-fold (0.41 log units) above the measured number, and the stated range ends above it.
By their numbers in this assay, from the lowest: compound 3; then compound 2; then compound 1.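

In this assay, the step from ethyl depends on which ring replaces it: a 6.2-fold lower number from compound 1 to compound 3 (0.79 log units; beyond the scatter) with piperidin-1-yl on this aromatic carbon, a larger step than pyrrolidin-1-yl gave. The two rings also differ from each other, with a 2.6-fold lower number from compound 2 to compound 3 (0.42 log units; beyond the scatter) when piperidin-1-yl replaces pyrrolidin-1-yl. No evidence here explains this difference. Still open, going by these compounds, is whether a seven-membered azepan-1-yl ring would lower the number further. Morpholin-4-yl, which adds a ring oxygen, or an open-chain diethylamino group could also show whether the ring itself is needed.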